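Ring-opened amine in the chloro-methoxyphenyl series

The compounds below may be only part of what the source reports. "The series", "measured", "known", "first", "only" and "open" are said of these compounds alone.

The series shares one core, here carrying an amine-bearing group on the chlorinated ring. Compound 1 `COc1ccccc1-c1cc(C2CCNC2)ccc1Cl` gives 770 nM in an assay on isolated protein for binding affinity to 5-hydroxytryptamine receptor 1E (Homo sapiens); on this read-out lower numbers stand for stronger inhibition and higher numbers for weaker inhibition; among the two numbers in hand this is the lowest. For the measured compounds named here, its nearest neighbour is compound 2 `COc1ccccc1-c1cc(C2CCN(C)C2)ccc1Cl`, which in this assay gives 4100 nM; the step of a 5.3-fold higher number from compound 1 to compound 2 (0.73 log units; beyond the scatter) is the only measured step and consists of a methyl in place of hydrogen on an amine nitrogen in a ring.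

Compound 3 `COc1ccccc1-c1cc(CN(C)C)ccc1Cl` is not yet measured in this assay. Relative to compound 1 the change is (dimethylamino)methyl in place of pyrrolidin-3-yl on an aromatic carbon. Going by the values given here, this change also removes the hydrogen from the amine nitrogen and replaces it with methyl, twice over, while opening the ring, so the step of a 5.3-fold higher number from compound 1 to compound 2 (0.73 log units; beyond the scatter) bears on it directly; no measured step speaks to the loss of the ring itself.

Because a 5.3-fold higher number from compound 1 to compound 2 (0.73 log units; beyond the scatter) was beyond the scatter and went upward, compound 3 is expected to give a higher number than compound 1, with the step of a 6.5-fold higher number from compound 1 to compound 3 (0.81 log units; beyond the scatter) estimated as modest. The expected value for compound 3 in this assay is 5000 nM, within a range of 1500 nM to 20000 nM.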

Compound 3, inhibition constant: 4100 nM
Beside the measured number, compound 3's estimate is 1.2-fold (0.09 log units) above it, and the stated range covers the measured number.
By their numbers in this assay, from the lowest: compound 1; then compounds 2 and 3 (each within the scatter of the next).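

In this assay, the ring itself carries no visible weight once the amine nitrogen is methylated: with (dimethylamino)methyl in place of 1-methylpyrrolidin-3-yl on this aromatic carbon, the result is no change at the digits printed from compound 2 to compound 3 (within the scatter). The ring-opened group also stands clear of the unsubstituted ring, with a 5.3-fold higher number from compound 1 to compound 3 (0.73 log units; beyond the scatter), a step of the same printed size as a 5.3-fold higher number from compound 1 to compound 2 (0.73 log units; beyond the scatter), so compound 1, the only one of the three whose group keeps a hydrogen on the amine nitrogen, remains the strongest binder here. No supporting measurement on these compounds bears on why the three values fall this way.

On these data alone, it remains open whether an open chain with a hydrogen on the nitrogen, such as (methylamino)methyl or aminomethyl, would match compound 1, which would separate the effect of the ring from that of the nitrogen substitution. As far as these compounds go, the effect of a longer chain, such as 2-(dimethylamino)ethyl, at this aromatic carbon also remains open.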